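The source may report more compounds than this note shows. Statements on the series, on what has been measured and on what is new or still open speak of the compounds shown alone.

Measured so far:
- compound 1, `CSc1ccccc1Nc1nc2c(Nc3ccc(C(F)(F)F)cc3)ncnc2s1`: 26 nM
- compound 2, `CSc1ccc(Nc2ncnc3sc(Nc4c(Cl)cccc4Cl)nc23)cc1`: 12 nM
- compound 3, `FC(F)(F)c1ccc(Nc2nc(N3CCCC3)nc3sc(Nc4c(Cl)cccc4Cl)nc23)cc1`: 36 nM

In a functional assay on HEK293 cells for antagonist activity at transient receptor potential cation channel subfamily V member 1 (Rattus norvegicus), read by calcium flux (a lower number here means a stronger inhibitor, a higher number a weaker inhibitor), compound 3 gives the highest of the three numbers. Its gap to compound 1 lies within the scatter of repeated measurements, so the two cannot be ranked against each other; its gap to compound 2, whose number is lower, lies beyond the scatter. Compound 4, `CC(C)Nc1nc(Nc2ccc(C(F)(F)F)cc2)c2nc(Nc3c(Cl)cccc3Cl)sc2n1`, is not yet measured. It differs from compound 3 in one place: isopropylamino in place of pyrrolidin-1-yl on an aromatic carbon. Among the measured compounds, no pair differs by exactly this change, so no measured step guides the expectation. A ring amine gives way to an open-chain amine of similar size that carries one hydrogen-bond donor where the ring had none. With nothing measured for this swap, the expected step of a 1.1-fold higher number from compound 3 to compound 4 (0.05 log units; within the scatter) is none beyond the scatter, and the number for compound 4 is estimated at 40 nM, expected between 12 nM and 130 nM.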

Compound 4, half-maximal inhibitory concentration: 9 nM
Compound 4: the middle estimate sits 4.4-fold (0.65 log units) above what was measured; the whole stated range lies above it.
By their numbers in this assay, from the lowest: compounds 4 and 2 (each within the scatter of the next); then compounds 1 and 3 (each within the scatter of the next).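

In this assay putting isopropylamino in place of pyrrolidin-1-yl, on the aromatic carbon between two ring nitrogen atoms, gives a 4.0-fold lower number from compound 3 to compound 4 (0.60 log units; beyond the scatter) and so shows that the group held at this position can change the reading. Among the compounds shown here, no earlier pair differed in one place, which makes this the only direct reading of a change here. The swap opens the ring and also brings a hydrogen-bond donor where the leaving group had none, and nothing at hand explains the step.

The two features change together, so this single step cannot say whether the ring or the donor matters more. A dimethylamino group, open-chain but with no amine hydrogen, or a plain amino group at this position would remain to be read before the two could be told apart.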